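Dimethoxyphenyl for fluorophenyl on the shared core

The source may hold more compounds than are shown below. What is called first, only, known or untested is meant among the compounds shown, and "the series" means these compounds.

Of the compounds shown here, three built on the same core have been tested in a functional assay on A549 cells (Homo sapiens) for cytotoxicity, read by MTT assay, with a stated time of 48 h; a higher number here means a weaker inhibitor, a lower number a stronger inhibitor. Compound 1 `COc1ccc(N/C(CCNC2=CC(=O)c3ccccc3C2=O)=N\S(=O)(=O)c2ccc(C)cc2)cc1` gives 25500 nM, compound 2 `Cc1ccc(S(=O)(=O)/N=C(/CCNC2=CC(=O)c3ccccc3C2=O)Nc2ccc(F)cc2)cc1` gives 9330 nM, and compound 3 `Cc1ccc(S(=O)(=O)/N=C(/CCNC2=CC(=O)c3ccccc3C2=O)Nc2ccccc2[N+](=O)[O-])cc1` gives 5010 nM. Compound 2 thus stands second highest of the three numbers, near compound 3 a 1.9-fold lower number from compound 2 to compound 3 (0.27 log units; within the scatter) and further from compound 1 a 2.7-fold lower number from compound 1 to compound 2 (0.44 log units; beyond the scatter). Compound 4 `COc1ccc(N/C(CCNC2=CC(=O)c3ccccc3C2=O)=N\S(=O)(=O)c2ccc(C)cc2)cc1OC` differs from compound 2 by 3,4-dimethoxyphenyl in place of 4-fluorophenyl on an amine nitrogen. Among the measured compounds shown here, the only bearing step is a 2.7-fold lower number from compound 1 to compound 2 (0.44 log units; beyond the scatter), where a methoxy group gave way to fluoro; compound 4 reverses that direction and adds a second methoxy, so a higher number is expected. Compound 4 is expected at 22000 nM (range 8000 nM to 60000 nM), an expected step of a 2.4-fold higher number from compound 2 to compound 4 (0.37 log units; beyond the scatter).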

Compound 4, half-maximal inhibitory concentration: 20500 nM
Estimate against measurement, compound 4: 1.1-fold (0.03 log units) above; the measured number falls inside the stated range.
By their numbers in this assay, from the lowest: compounds 3 and 2 (each within the scatter of the next); then compounds 4 and 1 (each within the scatter of the next).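

The second methoxy group gives no readable difference (a 1.2-fold lower number from compound 1 to compound 4 (0.09 log units; within the scatter)), so the 3,4-dimethoxyphenyl and 4-methoxyphenyl groups cannot be told apart on this amine nitrogen. Compound 4 also carries a higher number than both other compounds (a 2.2-fold higher number from compound 2 to compound 4 (0.34 log units; beyond the scatter); a 4.1-fold higher number from compound 3 to compound 4 (0.61 log units; beyond the scatter)), which places compound 1 and compound 4, the two methoxy-bearing compounds, apart from compound 2 and compound 3. Nothing measured here accounts for that separation. Going by these compounds, what a cyclohexyl group or a pyridyl ring would give on this amine nitrogen remains open.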